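Urea Capping on a Lysine-Derived Thiazole Amide

The source may hold more compounds than are shown below. What is called first, only, known or untested is meant among the compounds shown, and "the series" means these compounds.

Compound 1 `N[C@@H](CCCCNS(N)(=O)=O)C(=O)Nc1nc(-c2ccccc2)cs1`: 1100 nM
Compound 2 `CCOC(=O)N[C@@H](CCCCNS(N)(=O)=O)C(=O)Nc1nc(-c2ccccc2)cs1`: 200 nM
Compound 3 `NS(=O)(=O)NCCCC[C@H](NC(=O)Nc1ccccc1)C(=O)Nc1nc(-c2ccccc2)cs1`: 560 nM

Three compounds share one core and differ only in what sits on the amine nitrogen. In an assay for inhibition of protein deacetylase HDAC6 (Homo sapiens) (a lower number here means a stronger inhibitor, a higher number a weaker inhibitor), compound 1, with a free amine, gives 1100 nM. Adding an ethoxycarbonyl cap brought a 5.5-fold lower number from compound 1 to compound 2 (0.74 log units; beyond the scatter), whereas the phenylcarbamoyl cap brought only a 2.0-fold lower number from compound 1 to compound 3 (0.29 log units; within the scatter). Between the two caps the step was a 2.8-fold higher number from compound 2 to compound 3 (0.45 log units; beyond the scatter). Compound 3 therefore stands second highest of the three numbers, close to compound 1 and clearly weaker than compound 2.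

Compound 4 `NS(=O)(=O)NCCCC[C@H](NC(=O)NCc1ccc(F)cc1)C(=O)Nc1nc(-c2ccccc2)cs1` keeps the urea cap of compound 3 but changes the group on its far nitrogen: 4-fluorobenzyl in place of phenyl on an amide-type nitrogen. Among the measured compounds shown here, no measured pair shows this particular change. What bears on it is that the three caps so far moved this assay only modestly, and the step from the ethoxy cap to the anilino cap shows that what sits on the carbonyl carbon of the cap matters. Going from anilino to (4-fluorobenzyl)amino is a change of similar kind, so a step within or just beyond the scatter is expected, with no firm direction; the estimate is a 1.2-fold lower number from compound 3 to compound 4 (0.09 log units; within the scatter).

For compound 4 the expected number is 450 nM, within a range from 150 nM to 1400 nM.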

Compound 4, half-maximal inhibitory concentration: 370 nM
Compound 4: the middle estimate sits 1.2-fold (0.09 log units) above what was measured, and the stated range covers the measured number.
By their numbers in this assay, from the lowest: compounds 2, 4, 3 and 1 (each within the scatter of the next, the first and the last beyond it).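

In this assay, the far nitrogen of the urea accepts a larger group without a clear shift: 4-fluorobenzyl in place of phenyl gives a 1.5-fold lower number from compound 3 to compound 4 (0.18 log units; within the scatter). Even so, this small step changes how the urea caps read against the other two compounds, since compound 3 lay within the scatter of compound 1 and beyond it from compound 2, while the new urea shows a 3.0-fold lower number from compound 1 to compound 4 (0.47 log units; beyond the scatter), beyond the scatter, and a 1.9-fold higher number from compound 2 to compound 4 (0.27 log units; within the scatter), within it. These comparisons describe the numbers only, and nothing available here explains them.

The change adds both a fluorine and a carbon link to the ring, so the compounds shown cannot assign the step to either one; plain benzyl and 4-fluorophenyl on the same nitrogen would separate the two. Also open, from the compounds shown here alone, is how this nitrogen responds to a longer chain such as 2-phenylethyl, or to a group of another kind, such as a small methyl or a ring bearing a carboxylic acid.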